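Cyclohexyl in Place of 4-Chlorophenyl: Expected Step

A few compounds are considered here, and "the series" means these few. Any claim that something is new, unique, unknown or untested is made for them only; others in the source may bear on it.

In a functional assay on NCI-H1299 cells (Homo sapiens) for cytotoxicity, read by MTT assay, with a stated time of 48 h (on this read-out lower numbers stand for stronger inhibition and higher numbers for weaker inhibition), three compounds have been measured:
compound 1 `O=C1C[C@H](OCc2cc(-c3ccccc3)no2)[C@H]2CO[C@@H]1O2` gives 9800 nM;
compound 2 `O=C1C[C@H](OCc2cc(/C=C/c3ccccc3)no2)[C@H]2CO[C@@H]1O2` gives 7100 nM;
compound 3 `O=C1C[C@H](OCc2cc(-c3ccc(Cl)cc3)no2)[C@H]2CO[C@@H]1O2` gives 9000 nM.

Compound 3 stands second highest of these three numbers. Its nearest neighbour is compound 1, with a 1.1-fold lower number from compound 1 to compound 3 (0.04 log units; within the scatter); its furthest is compound 2, with a 1.3-fold higher number from compound 2 to compound 3 (0.10 log units; within the scatter). The remaining step, a 1.4-fold lower number from compound 1 to compound 2 (0.14 log units; within the scatter), is likewise within the scatter.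

Compound 4 `O=C1C[C@H](OCc2cc(C3CCCCC3)no2)[C@H]2CO[C@@H]1O2` differs from compound 3 in one place: cyclohexyl in place of 4-chlorophenyl on an aromatic carbon. Every measured step in this series alters the group at the same aromatic carbon, and none moved the number beyond the scatter. Compound 4 is therefore expected to show no change at the digits printed from compound 3 to compound 4 (within the scatter) in this assay, no step beyond the scatter. The estimate for compound 4 is 9000 nM, with a range from 4000 nM to 20000 nM.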

Compound 4, half-maximal inhibitory concentration: 6100 nM
The estimate for compound 4 lay 1.5-fold (0.17 log units) above the measured number; measured number inside the range.
By their numbers in this assay, from the lowest: compounds 4, 2, 3 and 1 (each within the scatter of the next).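

In this assay, a six-membered non-aromatic ring of carbon only takes the place of the aromatic rings at this carbon without any step beyond the scatter (a 1.5-fold lower number from compound 3 to compound 4 (0.17 log units; within the scatter); a 1.2-fold lower number from compound 2 to compound 4 (0.07 log units; within the scatter); a 1.6-fold lower number from compound 1 to compound 4 (0.21 log units; within the scatter)). The earlier compounds shown here all carried an aromatic ring in this group, so only compound 4 shows that this ring need not be aromatic to stay within the scatter. No measurement offered here explains this result. Going by these compounds, whether an amine, a carboxylic acid or a longer alkyl chain at this carbon would move the number beyond the scatter remains open.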